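This account rests on a few compounds, and the source may have more. Where it says the series, first, only, none or still open, it means among the compounds named here.

Measured compounds:
compound 1 `COc1ccc(-n2cc(CSC(=S)N3CCN(C(=O)OC(C)(C)C)CC3)nn2)cc1` gives > 128000 nM in a functional assay on PC-3 cells (Homo sapiens) for inhibition, read by MTT assay, with a stated time of 72 h (on this read-out lower numbers stand for stronger inhibition and higher numbers for weaker inhibition), a limit of the assay.
compound 2 `COc1ccc(Cn2cc(CSC(=S)N3CCN(C(=O)OCc4ccccc4)CC3)nn2)cc1` gives > 128000 nM in this assay, a limit.
compound 3 `Cc1ccc(-n2cc(CSC(=S)N3CCN(C(=O)OC(C)(C)C)CC3)nn2)cc1` gives > 128000 nM in this assay, a limit.

Compound 2 therefore stands only at a limit in this assay, as do the two other values shown; all three sit at the limit of > 128000 nM in this assay, at which 3 of the 3 values shown sit. For the measured compounds named here, the one measured step, a step that the two limits leave unreadable from compound 1 to compound 3, is unreadable between two limits. Compound 4 `COc1cc(Cn2cc(CSC(=S)N3CCN(C(=O)OCc4ccccc4)CC3)nn2)cc(OC)c1OC` differs from compound 2 by 3,4,5-trimethoxyphenyl in place of 4-methoxyphenyl on a saturated chain carbon bound to an aromatic nitrogen. Going by the values given here, no measured step concerns this change, so nothing bears on its size or direction; the only guide is that every value shown is a limit. Compound 4 is expected to give about 100000 nM in this assay, with a range from 20000 nM to 200000 nM. The expected step is an at least 1.2-fold lower number from compound 2 to compound 4 (0.10 log units; that floor lies within the scatter), most likely again a limit.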

Compound 4, half-maximal inhibitory concentration: > 128000 nM
Compound 4 ended at the assay's limit; the forecaster's own chance of this, stated with the estimate: 70%; middle value at least 1.2-fold (0.10 log units) from the limit.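

For the compounds shown here, compound 2 and compound 4 both stand at a limit, so no step between them can be read: the limit of > 128000 nM in this assay, at which 4 of the 4 values shown sit. The compounds shown leave open whether 3,4,5-trimethoxyphenyl in place of 4-methoxyphenyl changes inhibition at all in this assay.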